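The source may hold more compounds than are shown below. What is called first, only, known or untested is meant among the compounds shown, and "the series" means these compounds.

Series of three analogues sharing one core, measured for antiproliferative effect in a functional assay on HL60/MX2 cells (Homo sapiens) for antiproliferative activity, read by MTT assay, with a stated time of 48 h; on this read-out higher numbers stand for weaker inhibition and lower numbers for stronger inhibition. Compound 1 `CN(C)CCn1c(N)c(-c2nc3cc(Cl)ccc3[nH]2)c2nc(C#N)c(C#N)nc21` carries a dimethylamino chain. Its result in this assay is reported only as a limit, > 50000 nM, which is the limit of > 50000 nM in this assay, at which 1 of the 3 values shown sits. Compound 2 `CCN(CC)CCn1c(N)c(-c2nc3cc(Cl)ccc3[nH]2)c2nc(C#N)c(C#N)nc21` gives 9290 nM in this assay, and compound 3 `CN(C)CCCn1c(N)c(-c2nc3cc(Cl)ccc3[nH]2)c2nc(C#N)c(C#N)nc21` gives 5310 nM. The change diethylamino in place of dimethylamino on a saturated chain carbon, two bonds along the chain from an aromatic nitrogen produced an at least 5.3-fold lower number from compound 1 to compound 2 (0.73 log units; beyond the scatter). The change (dimethylamino)methyl in place of dimethylamino on a saturated chain carbon, two bonds along the chain from an aromatic nitrogen produced an at least 9.4-fold lower number from compound 1 to compound 3 (0.97 log units; beyond the scatter). Between the two measured numbers, a 1.7-fold lower number from compound 2 to compound 3 (0.24 log units; within the scatter), so no order is drawn from them.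

Compound 4 `CCN(CC)CCCn1c(N)c(-c2nc3cc(Cl)ccc3[nH]2)c2nc(C#N)c(C#N)nc21` is not yet measured. It differs from compound 3 by diethylamino in place of dimethylamino on a saturated chain carbon, three bonds along the chain from an aromatic nitrogen. This is the same kind of change as diethylamino in place of dimethylamino on a saturated chain carbon, two bonds along the chain from an aromatic nitrogen, which made an at least 5.3-fold lower number from compound 1 to compound 2 (0.73 log units; beyond the scatter); the place is not identical, since there it sits two bonds along the chain from an aromatic nitrogen and here three bonds along the chain from an aromatic nitrogen. The cores of the two pairs differ as given under ((dimethylamino)methyl in place of dimethylamino on a saturated chain carbon, two bonds along the chain from an aromatic nitrogen).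

For compound 4 the expected step is a 2.1-fold lower number from compound 3 to compound 4 (0.33 log units; beyond the scatter), resting on compound 1 going to compound 2 with an at least 5.3-fold lower number from compound 1 to compound 2 (0.73 log units; beyond the scatter), tempered by compound 3 already standing at 5310 nM. Compound 4 is estimated at 2500 nM, between 800 nM and 8000 nM.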

Compound 4, half-maximal inhibitory concentration: 2460 nM
For compound 4 the middle estimate is 1.0-fold (0.01 log units) above the measured one, and the stated range covers the measured number.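

In this assay, diethylamino in place of dimethylamino on the 3-(dimethylamino)propyl chain gives a 2.2-fold lower number from compound 3 to compound 4 (0.33 log units; beyond the scatter), so the direction of the change carries from one core to the other: the same change on two cores in this assay, an at least 5.3-fold lower number (0.73 log units; beyond the scatter) from compound 1 to compound 2 and a 2.2-fold lower number (0.33 log units; beyond the scatter) from compound 3 to compound 4; the limit leaves it open whether they differ Compound 1 is reported only as a limit, so whether the size of the step carries over stays unsettled: the limit of > 50000 nM in this assay, at which 1 of the 4 values shown sits. With diethylamino held, the 3-(diethylamino)propyl chain in place of 2-(diethylamino)ethyl gives a 3.8-fold lower number from compound 2 to compound 4 (0.58 log units; beyond the scatter), while the step that combines both differences, an at least 20-fold lower number from compound 1 to compound 4 (1.30 log units; beyond the scatter), rests on the same limit.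

The compounds shown leave open whether the change holds for a ring amine such as piperidine or morpholine in place of diethylamino, or on a chain longer than 3-(diethylamino)propyl. They also leave open how a primary amine at the chain end would read in this assay.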